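Swapping the isopropyl on cyanoguanidine nitrogen for furanylmethyl

The source may hold more compounds than are shown below. What is called first, only, known or untested is meant among the compounds shown, and "the series" means these compounds.

The three measured compounds share a core and differ only in the group on the double-bonded nitrogen. Compound 1 `CC(C)/N=C(\NC#N)Nc1cccnc1` in a functional assay on the whole organism (blood, strain Wistar-Okamoto) with Rattus norvegicus as the target, with a stated time of 5 days (on this read-out lower numbers stand for an effect already at smaller amounts and higher numbers for an effect only at larger amounts of compound), gives 2.5 mg/kg. Compound 2 `CC(/N=C(/NC#N)Nc1cccnc1)C(C)(C)C` in this assay gives 1 mg/kg, and compound 3 `CC(C)CC(C)(C)/N=C(\NC#N)Nc1cccnc1` in this assay gives 2.5 mg/kg. Compound 1 therefore stands level with compound 3, the two together at the highest number of the three, while compound 2 lies a clear distance lower.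

Compound 4 `N#CN/C(=N\Cc1ccco1)Nc1cccnc1` is not yet measured. It differs from compound 1 in one place: (furan-2-yl)methyl in place of isopropyl on a double-bonded nitrogen. For the measured compounds named here, the only step on record that changes the group at this nitrogen is no change at the digits printed from compound 1 to compound 3 (within the scatter); enlarging the alkyl there leaves the number where it was. Compound 2 carries yet another alkyl and sits lower, so the alkyl variations seen so far span only a narrow band. Going by the values given here, no measured step introduces an aromatic ring at this position, so the effect of the furan ring is unknown.

Compound 4 is therefore expected to stay close to compound 1, with a step of no change at the digits printed from compound 1 to compound 4 (within the scatter) that is likely within the scatter. The estimate for compound 4 in this assay is 2.5 mg/kg, with a range from 1 mg/kg to 10 mg/kg.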

Compound 4, minimum effective dose: 20 mg/kg
Beside the measured number, compound 4's estimate is 8.0-fold (0.90 log units) below it; measured number above the stated range.
By their numbers in this assay, from the lowest: compound 2; then compounds 1 and 3 (each within the scatter of the next); then compound 4.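

In this assay, for the compounds shown here, the group on the double-bonded nitrogen turns out to matter more than the earlier compounds showed. Isobutyl on the saturated chain carbon gives no change at the digits printed from compound 1 to compound 3 (within the scatter), whereas (furan-2-yl)methyl in place of isopropyl gives an 8.0-fold higher number from compound 1 to compound 4 (0.90 log units; beyond the scatter), so compound 4 needs a larger dose for an effect. This position therefore accepts a larger alkyl group in compound 3 without a shift in the number, but not every replacement of isopropyl, and the record offers no measured basis for explaining the loss seen with the furan-bearing group.

The single change brings in a five-membered aromatic ring, a ring oxygen and a methylene link together, so the compounds shown do not say which of these goes with the higher number. Benzyl would keep an aromatic ring without the oxygen, tetrahydrofuran-2-ylmethyl would keep the oxygen without the aromatic ring, and 2-(furan-2-yl)ethyl would show what a longer link does, but none of these groups is among the compounds shown here.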